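Larger ether group on the shared core: compound 4

This account rests on a few compounds, and the source may have more. Where it says the series, first, only, none or still open, it means among the compounds named here.

Values in a functional assay on A549 cells (Homo sapiens) for antiproliferative activity, read by MTT assay, with a stated time of 48 h (a lower number here means a stronger inhibitor, a higher number a weaker inhibitor), so far
compound 1 `COc1cc(-c2nnc3c(OC)cc(-c4ccc5c(ccn5C)c4)cn23)cc(OC)c1OC` gives 69 nM
compound 2 `COc1cc(-c2nnc3c(OC(C)C)cc(-c4ccc5c(ccn5C)c4)cn23)cc(OC)c1OC` gives 322 nM
compound 3 `COc1cc(-c2nnc3c(OC4CC4)cc(-c4ccc5c(ccn5C)c4)cn23)cc(OC)c1OC` gives 168 nM
compound 4 `CCCN1CC(Oc2cc(-c3ccc4c(ccn4C)c3)cn3c(-c4cc(OC)c(OC)c(OC)c4)nnc23)C1` is not yet measured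

On these numbers, compound 3 lies within the scatter of compound 2, and both carry higher numbers than compound 1. Compound 4 has 1-propylazetidin-3-yl in place of cyclopropyl on an oxygen on an aromatic ring. Among the compounds with values here, three measured steps concern this same oxygen substituent. Two are modest and beyond the scatter: a 4.7-fold higher number from compound 1 to compound 2 (0.67 log units; beyond the scatter) and a 2.4-fold higher number from compound 1 to compound 3 (0.39 log units; beyond the scatter). The third stays within it: a 1.9-fold lower number from compound 2 to compound 3 (0.28 log units; within the scatter). Within the data shown here, both replacements of methyl raised the number, though that rests on only three compounds. Among the measured compounds shown here, no measured compound carries a ring with a hetero atom on this oxygen, so the size of the next step is poorly constrained. A modest rise in this assay is expected, with a wide margin. The expected step is a 2.3-fold higher number from compound 3 to compound 4 (0.35 log units; beyond the scatter). For compound 4 the estimated value is 380 nM, with an expected range of 110 nM to 1300 nM.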

Compound 4, half-maximal inhibitory concentration: 234 nM
The estimate for compound 4 lay 1.6-fold (0.21 log units) above the measured number; the range from low to high includes it.
By their numbers in this assay, from the lowest: compound 1; then compounds 3, 4 and 2 (each within the scatter of the next).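

In this assay, the oxygen on the aromatic ring accepts 1-propylazetidin-3-yl, with 7 heavy atoms and a ring nitrogen, without a change that can be read against the smaller ethers: a 1.4-fold higher number from compound 3 to compound 4 (0.14 log units; within the scatter) and a 1.4-fold lower number from compound 2 to compound 4 (0.14 log units; within the scatter). Against methyl the step is a 3.4-fold higher number from compound 1 to compound 4 (0.53 log units; beyond the scatter), so all three replacements of methyl in this set give a higher number, and no compound shown goes against this. Nothing available explains why the hetero atom and the added size leave the number within the scatter of compound 2 and compound 3.

Going by these compounds, it remains open whether the ring nitrogen or the propyl chain matters here. An oxetan-3-yl ether or a 1-methylazetidin-3-yl ether on the same oxygen would separate the two.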